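A few compounds are considered here, and "the series" means these few. Any claim that something is new, unique, unknown or untested is made for them only; others in the source may bear on it.

The three measured compounds share one core and differ around it. Compound 1 `CCOc1cc([C@](O)(CCN(C)C)[C@H](c2cccc(C)c2)c2cc3cc(Br)ccc3nc2OC)cc(OC)n1`, compound 2 `COc1cc([C@](O)(CCN(C)C)[C@@H](c2cc3cc(C#N)ccc3nc2OC)c2cccc(C)c2F)cc(OC(F)F)n1` and compound 3 `COc1cc([C@](O)(CCN(C)C)[C@@H](c2cc3cc(C#N)ccc3nc2OC)c2ccnc(OC)c2OC)cc(OC(F)F)n1` were all run in an ADME assay on microsomes from liver (Mus musculus) for metabolic stability; a lower number here means slower removal, a higher number faster removal of the compound. There compound 1 gives 7.8 uL/min, compound 2 gives 5.9 uL/min and compound 3 gives 11 uL/min. Compound 2 has the lowest of the three numbers, though its distance to compound 1 and to compound 3 stays within the scatter, so no ranking can be claimed among them. Going by the values given here, the only single-point step is a 1.9-fold higher number from compound 2 to compound 3 (0.27 log units; within the scatter).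

Compound 4 `COc1nc2ccc(C#N)cc2cc1[C@@H](c1cccc(C)c1F)[C@@](O)(CCN(C)C)c1cc(SC)nc(SC)c1` has not yet been measured. It differs from compound 2 in this way: a group of 10 heavy atoms (7 carbon, 1 nitrogen, 2 sulfur; one six-membered aromatic ring with 1 hetero atom) in place of a group of 12 heavy atoms (7 carbon, 1 nitrogen, 2 oxygen, 2 fluorine; one six-membered aromatic ring with 1 hetero atom), on a saturated chain carbon bound to an oxygen on a saturated carbon and two saturated chain carbons. Among the compounds with values here, no measured step touches this position; the one known step, from compound 2 to compound 3, changes a different group and stays within the scatter. With nothing pointing in either direction, compound 4 is expected to give about 8 uL/min, between 3.5 uL/min and 18 uL/min, an estimated step of a 1.4-fold higher number from compound 2 to compound 4 (0.13 log units; within the scatter).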

Compound 4, intrinsic clearance in a liver preparation (reported as CLH), per the amount of preparation that the assay uses: 13 uL/min
Beside the measured number, compound 4's estimate is 1.6-fold (0.21 log units) below it; measured number inside the range.
By their numbers in this assay, from the lowest: compounds 2, 1, 3 and 4 (each within the scatter of the next, the first and the last beyond it).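

In this assay, going by these compounds alone, this is the first measured change on the saturated chain carbon bound to an oxygen on a saturated carbon and two saturated chain carbons, and a 2.2-fold higher number from compound 2 to compound 4 (0.34 log units; beyond the scatter) shows that the group held there can move the number modestly beyond the scatter. The entering group of 10 heavy atoms (7 carbon, 1 nitrogen, 2 sulfur) and the leaving group of 12 heavy atoms (7 carbon, 1 nitrogen, 2 oxygen, 2 fluorine) have the same counts of hydrogen-bond donors and acceptors, so the step appears with those counts unchanged. No measurement shown here gives a reason for this step.

With a single step at this place, the compounds shown cannot separate the contribution of the sulfur atoms from that of the departing oxygen and fluorine atoms. From the compounds shown here alone, how a ring carrying an amine or a carboxylic acid would behave at this place also remains open.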